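This account rests on a few compounds, and the source may have more. Where it says the series, first, only, none or still open, it means among the compounds named here.

Measured so far:
- compound 1 `CCNC(=O)C1=C(C)NC(=O)NC1c1cccs1` gives 1% in an assay on membranes from HEK293 cells for displacement of a labelled ligand from adenosine receptor A2b (Homo sapiens), read by scintillation counting, with a stated time of 30 min, tested at 1 uM; on this read-out higher numbers stand for more inhibition at the one concentration tested (going by the name of the read-out) and lower numbers for less inhibition
- compound 2 `CCSC(=O)C1=C(C)NC(=O)NC1c1cccs1` gives 1% in this assay

Compound 2 stands level with compound 1 at the digits printed; the step of no change at the digits printed from compound 1 to compound 2 (within the scatter), ethylsulfanyl in place of ethylamino on a carbonyl carbon, stayed within the scatter, so neither compound shows any inhibition to speak of.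

Compound 3 `CC1=C(C(=O)SC(C)C)C(c2cccs2)NC(=O)N1` differs from compound 2 in one place: methyl in place of hydrogen on a saturated chain carbon bound to a saturated chain carbon and a sulfur. For the measured compounds named here, no measured step touches this chain carbon. Going by the values given here, the only measured step, no change at the digits printed from compound 1 to compound 2 (within the scatter), was within the scatter, and with compound 2 already near the floor there is no basis for expecting movement. The expected step is a number 1 percentage points higher from compound 2 to compound 3 (within the scatter), none beyond the scatter. Compound 3 is estimated at 2%, range -8% to 12%.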

Compound 3, a percentage reported as inhibition, at one concentration (the size of the read-out at that concentration, not a potency): 1%
Compound 3: middle estimate off by 1 percentage points, on the high side; the range from low to high includes it.
By their numbers in this assay, from the lowest: compounds 1, 2 and 3 (each within the scatter of the next).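

With this assay as the read-out, methyl on the saturated chain carbon bound to a saturated chain carbon and a sulfur gives no change at the digits printed from compound 2 to compound 3 (within the scatter), and isopropylsulfanyl in place of ethylamino on the carbonyl carbon gives no change at the digits printed from compound 1 to compound 3 (within the scatter). Ethyl to isopropyl on the sulfur therefore lifts nothing off the floor of this read-out at the one concentration tested. No evidence here bears on these results.

Open, as far as these compounds go, is whether a longer chain such as butyl on the sulfur would give a reading beyond the scatter. Also open, from the compounds shown here alone, is whether a carboxylic acid in place of the isopropylsulfanyl carbonyl would do so.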